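The source may report more compounds than this note shows. Statements on the series, on what has been measured and on what is new or still open speak of the compounds shown alone.

Compound 1 `O=c1cc(Cc2c(F)cccc2Cl)nc(SC2CCCC2)[nH]1` and compound 2 `Cc1c(Cc2c(F)cccc2Cl)nc(SC2CCCC2)[nH]c1=O` share one core and differ in a single change: methyl in place of hydrogen on an aromatic carbon. In an ADME assay on MT4 cells (Homo sapiens) for activation, read by MTT assay (on this read-out higher numbers stand for lower toxicity in this test and lower numbers for higher toxicity in this test), compound 1 gives only a limit of > 74000 nM. Compound 2 likewise gives only a limit of > 71000 nM in this assay. The step that the two limits leave unreadable from compound 1 to compound 2 cannot be sized, since it rests on two limits, the limit of > 74000 nM in this assay, at which 1 of the 3 values shown sits, and (the limit of > 71000 nM in this assay, at which 1 of the 3 values shown sits). Compound 3 `CC(C)Sc1nc(C(C)c2c(F)cccc2Cl)cc(=O)[nH]1` has another core; the difference between the two cores is not broken down here. In this assay compound 3 gives only a limit of > 75000 nM, (the limit of > 75000 nM in this assay, at which 1 of the 3 values shown sits). Compound 4 `Cc1c(C(C)c2c(F)cccc2Cl)nc(SC(C)C)[nH]c1=O` is not yet measured and differs from compound 3 by methyl in place of hydrogen on an aromatic carbon. Among the measured compounds shown here, this is the same kind of change as the one from compound 1 to compound 2, not the same: here the methyl is ortho to a large group and para to an isopropylsulfanyl group (4 heavy atoms), whereas there it was ortho to a group of 9 heavy atoms and para to a cyclopentylsulfanyl group (6 heavy atoms). The expected step of a number no higher from compound 3 to compound 4 (the limit leaves the size open) is small, resting on the two limits the limit of > 71000 nM in this assay, at which 1 of the 3 values shown sits, and (the limit of > 74000 nM in this assay, at which 1 of the 3 values shown sits). For compound 4 the estimate in this assay is 75000 nM, between 50000 nM and 150000 nM, most likely reported again only as a limit.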

Compound 4, half-maximal cytotoxic concentration: > 15000 nM
Compound 4: no number, only a limit (the forecaster's own chance of this, stated with the estimate: 85%); the middle value does not contradict the limit.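

Compound 3 and compound 4 both give only limits in this assay, so the size of the step between them cannot be read. The compounds shown leave open whether methyl in place of hydrogen on an aromatic carbon shifts the half-maximal cytotoxic concentration at all, and where that concentration lies for any of them.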